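The source may report more compounds than this note shows. Statements on the series, on what has been measured and on what is new or still open speak of the compounds shown alone.

Working notes on the series. The shared core carries a methyl on the six-membered carbon ring, or a hydrogen in its place. In a functional assay on NCI-H460 cells (Homo sapiens) for cytotoxicity, read by MTT assay, with a stated time of 48 h (on this read-out higher numbers stand for weaker inhibition and lower numbers for stronger inhibition), compound 1 `O=c1[nH]c2ccccc2cc1-c1nc2cc(F)ccc2[nH]1` gives 24200 nM. Compound 3 `Cc1ccc2[nH]c(=O)c(-c3nc4cc(F)ccc4[nH]3)cc2c1` reaches only a limit of > 100000 nM in this assay. Compound 2 `Cc1ccc2[nH]c(=O)c(-c3nc4cc(C)c(C)cc4[nH]3)cc2c1` likewise reaches only a limit of > 100000 nM in this assay. The difference between the cores of compound 2 and compound 3 is not broken down here. The change hydrogen in place of methyl on an aromatic carbon gave an at least 4.1-fold lower number from compound 3 to compound 1 (0.61 log units; beyond the scatter), an at-least figure given (the limit of > 100000 nM in this assay, at which 2 of the 3 values shown sit). Compound 4 `Cc1cc2nc(-c3cc4ccccc4[nH]c3=O)[nH]c2cc1C` arises from compound 2 by the same change, (hydrogen in place of methyl on an aromatic carbon). For compound 4 a step like an at least 2.5-fold lower number from compound 2 to compound 4 (0.39 log units; beyond the scatter) is expected in this assay, resting on the move from compound 3 to compound 1 of an at least 4.1-fold lower number from compound 3 to compound 1 (0.61 log units; beyond the scatter). Compound 4 is therefore estimated at 40000 nM in this assay, within 10000 nM to 150000 nM.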

Compound 4, half-maximal inhibitory concentration: > 100000 nM
Compound 4: no number, only a limit; the forecaster's own chance of this, stated with the estimate: 35%; middle value at least 2.5-fold (0.39 log units) away from the limit.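

In this assay compound 4 gives > 100000 nM, a limit. Compound 2 also sits at a limit, so no step can be read from compound 2 to compound 4: the limit of > 100000 nM in this assay, at which 3 of the 4 values shown sit. On these data alone, whether hydrogen in place of methyl changes the number from compound 2 to compound 4 stays open.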